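Pyrrolidine amide swap carried onto the aminopyridine core

The source may report more compounds than this note shows. Statements on the series, on what has been measured and on what is new or still open speak of the compounds shown alone.

Compound 1 `C[C@H](NC(=O)C1CCOCC1)c1ccc(NC(=O)N2CC(c3cccnc3)C2)cc1` gives 58 mL.min-1.g-1 in an ADME assay on microsomes from liver (Mus musculus) for pharmacokinetics, read by LC-MS, using NADPH, with stated times of 5 min, 15 min and 30 min, tested at 10 uM; on this read-out higher numbers stand for fast clearance and lower numbers for slow clearance. Compound 2 `C[C@H](NC(=O)[C@@H]1CCCN1C)c1ccc(NC(=O)N2CC(c3cccnc3)C2)cc1` gives 40.8 mL.min-1.g-1 in this assay, the change being (1-methylpyrrolidin-2-yl in place of oxan-4-yl on a carbonyl carbon), with the step of a 1.4-fold lower number from compound 1 to compound 2 (0.15 log units; within the scatter). Compound 3 `C[C@H](NC(=O)C1CCOCC1)c1ccc(NC(=O)N2CC(c3cncc(N)c3)C2)cc1` gives 60.2 mL.min-1.g-1 in this assay; its core differs from that of compound 1 by amino in place of hydrogen on an aromatic carbon, and the step is a 1.0-fold higher number from compound 1 to compound 3 (0.02 log units; within the scatter). Compound 4 `C[C@H](NC(=O)[C@@H]1CCCN1C)c1ccc(NC(=O)N2CC(c3cncc(N)c3)C2)cc1` carries the same change onto the core of compound 3, namely (1-methylpyrrolidin-2-yl in place of oxan-4-yl on a carbonyl carbon), at a place described in the same words as before. Compound 4 has not yet been measured in this assay. For compound 4 the expected step is a 1.4-fold lower number from compound 3 to compound 4 (0.15 log units; within the scatter), resting on the earlier 1.4-fold lower number from compound 1 to compound 2 (0.15 log units; within the scatter), which lay within the scatter. Compound 4 is estimated at 43 mL.min-1.g-1, with a range from 24 mL.min-1.g-1 to 78 mL.min-1.g-1.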

Compound 4, intrinsic clearance in microsomes: 47.4 mL.min-1.g-1
Compound 4: the middle estimate sits 1.1-fold (0.04 log units) below what was measured; low and high end bracket the measured number.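

Carried onto the core of compound 3, 1-methylpyrrolidin-2-yl in place of oxan-4-yl on a carbonyl carbon gives a 1.3-fold lower number from compound 3 to compound 4 (0.10 log units; within the scatter) in this assay, and this agrees with the earlier step: the same change on two cores in this assay, a 1.4-fold lower number (0.15 log units; within the scatter) from compound 1 to compound 2 and a 1.3-fold lower number (0.10 log units; within the scatter) from compound 3 to compound 4, 1.1-fold (0.05 log units) apart, within the scatter of two such steps

Amino in place of hydrogen on an aromatic carbon gives a 1.2-fold higher number from compound 2 to compound 4 (0.07 log units; within the scatter), and this also agrees with the earlier step: the same change on two cores in this assay, a 1.0-fold higher number (0.02 log units; within the scatter) from compound 1 to compound 3 and a 1.2-fold higher number (0.07 log units; within the scatter) from compound 2 to compound 4, 1.1-fold (0.05 log units) apart, within the scatter of two such steps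

All these steps lie within the scatter, so the data show agreement on these two cores, not a measurable effect of either change that carries over, and they say nothing about other cores.

Open, going by these compounds, is whether a carboxylic acid or a longer amine chain on the carbonyl carbon gives a larger step. Also open, on these data alone, is how the other stereoisomer of 1-methylpyrrolidin-2-yl reads in this assay.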